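Adding Two Methyl Groups to a Cyclohexyl Ring

The source may report more compounds than this note shows. Statements on the series, on what has been measured and on what is new or still open speak of the compounds shown alone.

Of the compounds shown here, two have been measured in a functional assay on cells for antagonist activity at C-X-C chemokine receptor type 4 (Homo sapiens), read by fluorescence and calcium flux, with stated times of 25 min and 90 s; a lower number here means a stronger inhibitor, a higher number a weaker inhibitor. Compound 1 `c1ccc(CNCCCCN(C[C@H]2Cc3ccccc3CN2)[C@H]2CCCc3cccnc32)cc1` gives 20.1 nM. Compound 2 `c1ccc2c(c1)CN[C@@H](CN(CCCCNC1CCCCC1)[C@H]1CCCc3cccnc31)C2`, which differs only where a cyclohexyl group replaces a benzyl group on an amine nitrogen, gives 75.2 nM; that change appears as a 3.7-fold higher number from compound 1 to compound 2 (0.57 log units; beyond the scatter). Compound 2 thus has the higher of the two numbers in this assay, and compound 1 the lower.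

Compound 3 `CC1(C)CCC(NCCCCN(C[C@H]2Cc3ccccc3CN2)[C@H]2CCCc3cccnc32)CC1` has not yet been measured. Its difference from compound 2 is 4,4-dimethylcyclohexyl in place of cyclohexyl on an amine nitrogen. For the measured compounds named here, no measured step covers this kind of change: the only step in hand, from benzyl to cyclohexyl, swaps one ring type for another, whereas here the cyclohexyl ring stays and only gains two methyl groups. The direction of this change cannot be read from the data, so no step beyond the scatter is anticipated in either direction. Compound 3 is therefore expected to give about 90 nM in this assay, within a range of 30 nM to 300 nM, which corresponds to an expected step of a 1.2-fold higher number from compound 2 to compound 3 (0.08 log units; within the scatter).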

Compound 3, half-maximal inhibitory concentration: 77.6 nM
Estimate against measurement, compound 3: 1.2-fold (0.06 log units) above; the measured number falls inside the stated range.
By their numbers in this assay, from the lowest: compound 1; then compounds 2 and 3 (each within the scatter of the next).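

In this assay, the cyclohexyl ring on this amine nitrogen can be replaced by 4,4-dimethylcyclohexyl, which has more carbon atoms, without a difference that can be distinguished from ordinary assay scatter (a 1.0-fold higher number from compound 2 to compound 3 (0.01 log units; within the scatter)). For the compounds shown here, this is the first measurement to show that the ring tolerates added carbon at this site, at least in this form, whereas the earlier step only exchanged benzyl for cyclohexyl. The disadvantage relative to benzyl also persists, since the step to 4,4-dimethylcyclohexyl (a 3.9-fold higher number from compound 1 to compound 3 (0.59 log units; beyond the scatter)) and the earlier step to cyclohexyl (a 3.7-fold higher number from compound 1 to compound 2 (0.57 log units; beyond the scatter)) both lie beyond the scatter and both leave compound 1 with the lower number, while no separate evidence is available to explain these results.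

These compounds leave open whether the tolerance extends to other changes on the saturated ring, such as a hydroxyl group or a 4,4-difluorocyclohexyl group, or to a smaller ring such as cyclopentyl. They also leave open whether an aromatic ring is what favours benzyl, a question that a pyridylmethyl group or a substituted benzyl group such as 4-fluorobenzyl on the same nitrogen could help to address.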